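The source may hold more compounds than are shown below. What is called first, only, known or untested is meant among the compounds shown, and "the series" means these compounds.

For the measured compounds named here, in an ADME assay on microsomes from liver (Mus musculus) for pharmacokinetics, read by LC-MS, using NADPH, with stated times of 5 min, 15 min and 30 min, tested at 10 uM (a lower number here means slower removal, a higher number faster removal of the compound), compound 1 `C[C@@H](c1ccc(NC(=O)N2CC(c3cccnc3)C2)cc1)N1Cc2ccccc2C1=O` gives 123 mL.min-1.g-1, the highest of the three numbers measured so far. Compound 2 `C[C@H](NC(=O)c1ncccn1)c1ccc(NC(=O)N2CC(c3cccnc3)C2)cc1` gives 28.9 mL.min-1.g-1, and compound 3 `C[C@H](NC(=O)C1CCOCC1)c1ccc(NC(=O)N2CC(c3cccnc3)C2)cc1` gives 58 mL.min-1.g-1. Both replace the group that compound 1 carries on its saturated chain carbon. The results, a 4.3-fold lower number from compound 1 to compound 2 (0.63 log units; beyond the scatter) and a 2.1-fold lower number from compound 1 to compound 3 (0.33 log units; beyond the scatter), are modest but beyond the scatter, while a 2.0-fold higher number from compound 2 to compound 3 (0.30 log units; within the scatter) lies within it.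

Compound 4 `C[C@@H](c1ccc(NC(=O)N2CC(c3cncc(N)c3)C2)cc1)N1Cc2ccccc2C1=O` keeps the group of compound 1 on that carbon and differs elsewhere: amino in place of hydrogen on an aromatic carbon. In other words, pyridin-3-yl becomes 5-aminopyridin-3-yl. Going by the values given here, no measured step touches this group, and no measured compound carries the amino group, so the steps bear on the change only indirectly and give no firm direction. The largest of them, a 4.3-fold lower number from compound 1 to compound 2 (0.63 log units; beyond the scatter), serves as a rough guide to the size that might be expected. With compound 1 at the top of the measured numbers at 123 mL.min-1.g-1, a small fall seems somewhat more likely than a rise, though a step beyond the scatter is not expected. The expected change is a 1.3-fold lower number from compound 1 to compound 4 (0.11 log units; within the scatter). For compound 4 the estimated value is 95 mL.min-1.g-1, with an expected range from 42 mL.min-1.g-1 to 210 mL.min-1.g-1.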

Compound 4, intrinsic clearance in microsomes: 158 mL.min-1.g-1
For compound 4 the middle estimate is 1.7-fold (0.22 log units) below the measured one, within the range that was stated.
By their numbers in this assay, from the lowest: compounds 2 and 3 (each within the scatter of the next); then compounds 1 and 4 (each within the scatter of the next).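

Amino in place of hydrogen, on an aromatic carbon two atoms from the ring nitrogen and meta to a large group, is the only measured change on the pyridin-3-yl group, and in this assay it gives a 1.3-fold higher number from compound 1 to compound 4 (0.11 log units; within the scatter). Compound 1 and compound 4 therefore cannot be told apart in this read-out, whereas the replacements on the saturated chain carbon, a 4.3-fold lower number from compound 1 to compound 2 (0.63 log units; beyond the scatter) and a 2.1-fold lower number from compound 1 to compound 3 (0.33 log units; beyond the scatter), are printed as beyond the scatter, so this single amino group does not match them as a way of separating a compound from compound 1. No other measurement is at hand to account for this result.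

As far as these compounds go, it remains open whether the amino group would read the same way on the compounds that carry the pyrimidine-2-carbonyl amide or the oxane-4-carbonyl amide of compound 2 and compound 3. From the compounds shown here alone, it also remains open whether another group on the same ring carbon, such as methoxy, fluoro or a carboxylic acid, would give a step beyond the scatter.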